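Swapping halogens on the aniline ring of compound 2

This account rests on a few compounds, and the source may have more. Where it says the series, first, only, none or still open, it means among the compounds named here.

For the measured compounds named here, compound 2 `Cc1n[nH]c2ccc(-c3nc4cnc(N5CCN(C)CC5)cn4c3Nc3ccc(F)c(Cl)c3)cc12` gives 84.1% in a functional assay on MV4-11 cells (Homo sapiens) for inhibition, with a stated time of 120 h, tested at 10 uM (on this read-out lower numbers stand for less inhibition and higher numbers for more inhibition at the one concentration tested (going by the name of the read-out)), the higher of the two numbers known here, while compound 1 `COc1ccc(Nc2c(-c3ccc4[nH]nc(C)c4c3)nc3cnc(N4CCN(C)CC4)cn23)cc1` gives 3.32%. Going by the values given here, the single measured step, a number 80.8 percentage points higher from compound 1 to compound 2 (beyond the scatter), shows that this aromatic ring on the nitrogen can move the read-out a great deal. Compound 3 `Cc1n[nH]c2ccc(-c3nc4cnc(N5CCN(C)CC5)cn4c3Nc3ccc(Cl)cc3Cl)cc12` differs from compound 2 by 2,4-dichlorophenyl in place of 3-chloro-4-fluorophenyl on a nitrogen on an aromatic ring. Among the compounds with values here, no measured step exchanges one halogenated ring for another, so the direction is uncertain. Compound 3 is expected to keep a high number in this assay, with an estimated step of a number 24.1 percentage points lower from compound 2 to compound 3 (beyond the scatter), giving an estimate of 60% between 15% and 90%.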

Compound 3, a percentage reported as inhibition, at one concentration (the size of the read-out at that concentration, not a potency): 78.8%
Compound 3: middle estimate off by 18.8 percentage points, on the low side, and the stated range covers the measured number.
By their numbers in this assay, from the lowest: compound 1; then compounds 3 and 2 (each within the scatter of the next).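

In this assay one halogenated ring is now exchanged for another, and a number 5.3 percentage points lower from compound 2 to compound 3 (within the scatter) means that 2,4-dichlorophenyl and 3-chloro-4-fluorophenyl on this nitrogen cannot be told apart. With a number 75.5 percentage points higher from compound 1 to compound 3 (beyond the scatter) a second halogenated ring also stands far from 4-methoxyphenyl, so the large gap is not tied to a single halogen pattern. No measurement at hand explains either step. Still open, from the compounds shown here alone, is how a plain phenyl ring, or one carrying a methyl group or a nitrile, would score at this position, which would show whether a halogen is needed at all.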